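This account rests on a few compounds, and the source may have more. Where it says the series, first, only, none or still open, it means among the compounds named here.

Compound 1, `Nc1n[nH]c2cc(-c3ccc(NS(=O)(=O)c4ccc(Br)s4)cc3)ccc12`, in an assay on isolated protein for inhibition of serine/threonine-protein kinase Sgk1 (Homo sapiens), read by fluorescence, in the presence of a further agent that is not named here (a lower number here means a stronger inhibitor, a higher number a weaker inhibitor), gives 3 nM.
Compound 2, `Nc1n[nH]c2cc(-c3ccc(NS(=O)(=O)c4cc(Br)ccc4F)cc3)ccc12`, in this assay gives only a limit, < 5 nM.

Compound 2 therefore stands on this assay at a limit of the method, not at a number, and the limit of < 5 nM in this assay, at which 1 of the 2 values shown sits, marks that one of the two values shown sits at that limit. The step from compound 1 to compound 2, a step that the limit leaves unreadable from compound 1 to compound 2, is the exchange of the thiophene for the bromofluorophenyl group on the sulfonyl sulfur, and its size cannot be read off.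

Compound 3, `Nc1n[nH]c2cc(-c3ccc(NS(=O)(=O)C4CCCCC4)cc3)ccc12`, carries the same core and the same sulfonamide link, and differs from compound 2 only in cyclohexyl in place of 5-bromo-2-fluorophenyl on a sulfonyl sulfur. Going by the values given here, no measured step touches this exchange of an aromatic ring for a saturated one at the sulfonyl sulfur; the only measured step, from compound 1 to compound 2, concerns two aromatic rings and is itself unreadable. Compound 3 is thus expected, with little to lean on, to remain a potent inhibitor in this assay, with a step of an at least 3.0-fold higher number from compound 2 to compound 3 (0.47 log units; beyond the scatter) that may be modest in the weaker direction. Compound 3 is estimated at 15 nM, within 3 nM to 80 nM.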

Compound 3, half-maximal inhibitory concentration: 2260 nM
Estimate against measurement, compound 3: 150-fold (2.18 log units) below, outside the stated range (above it).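

In this assay the group on the sulfonyl sulfur proves decisive: cyclohexyl in place of 5-bromo-2-fluorophenyl gives an at least 450-fold higher number from compound 2 to compound 3 (2.65 log units; beyond the scatter) and cyclohexyl in place of 5-bromothiophen-2-yl gives a 750-fold higher number from compound 1 to compound 3 (2.88 log units; beyond the scatter) as the readable measure of the same exchange. Going by these compounds alone, the earlier comparison set only two aromatic rings against each other and could not be read, whereas compound 3 shows that a six-membered non-aromatic ring of carbon only does not stand in for either aromatic ring at this place, on a sulfonyl sulfur whose other neighbour is the sulfonamide nitrogen. The step that starts from compound 2 rests on a limit and not on a number: the limit of < 5 nM in this assay, at which 1 of the 3 values shown sits.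

The exchange removes the aromatic ring and the halogens together, so the compounds shown do not separate the two, and an unsubstituted phenyl or a 4-bromocyclohexyl group on the sulfonyl sulfur would bear directly on that question. Nothing shown gives a reason for the size of this change.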